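Amide side chains: from compound 1 to compound 4

The compounds below may be only part of what the source reports. "The series", "measured", "known", "first", "only" and "open" are said of these compounds alone.

Values in a functional assay on CLL cells (Homo sapiens) for cytotoxicity, read by MTT assay, with a stated time of 48 h; a higher number here means that more compound is needed for the effect, a lower number that less compound is needed:
- compound 1 `C=C(CC)C(=O)c1ccc(OCC(=O)NCC(=O)O)c(Cl)c1Cl`: > 25000 nM (a limit)
- compound 2 `C=C(CC)C(=O)c1ccc(OCC(=O)Nc2ccc(C(=O)O)cc2)c(Cl)c1Cl`: 5000 nM
- compound 3 `C=C(CC)C(=O)c1ccc(OCC(=O)Nc2ccc(C(C)=O)cc2)c(Cl)c1Cl`: 3900 nM

Compound 1 sits at the limit of > 25000 nM in this assay, at which 1 of the 3 values shown sits. Compound 4 `C=C(CC)C(=O)c1ccc(OCC(=O)NCC2CCC(C(=O)O)CC2)c(Cl)c1Cl` keeps the core of compound 1 and differs by 4-carboxycyclohexyl in place of carboxy on a saturated chain carbon bound to an amide-type nitrogen. Going by the values given here, two measured steps bear on this change: an at least 5.0-fold lower number from compound 1 to compound 2 (0.69 log units; beyond the scatter) and an at least 6.4-fold lower number from compound 1 to compound 3 (0.80 log units; beyond the scatter). Among the compounds with values here, both introduce an aromatic ring, and no measured compound carries a non-aromatic one. In addition, a 1.3-fold lower number from compound 2 to compound 3 (0.11 log units; within the scatter). A step towards lower numbers is therefore expected, similar to these or somewhat smaller. The expected step is an at least 3.1-fold lower number from compound 1 to compound 4 (0.49 log units; beyond the scatter). The estimate for compound 4 is 8000 nM, with an expected range of 3000 nM to 25000 nM.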

Compound 4, half-maximal effective concentration: 8000 nM
Compound 4: the middle estimate sits on the measured number at the digits printed; the measured number falls inside the stated range.
By their numbers in this assay, from the lowest: compounds 3, 2 and 4 (each within the scatter of the next, the first and the last beyond it). At a limit, above all of these: compound 1.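

In this assay, the step to lower numbers does not depend on an aromatic ring: an at least 3.1-fold lower number from compound 1 to compound 4 (0.49 log units; beyond the scatter). Going by these compounds alone, the 4-carboxycyclohexyl group has a six-membered non-aromatic ring of carbon only and keeps a carboxylic acid, a combination that the earlier compounds did not cover. Compound 1 stands at a limit: the limit of > 25000 nM in this assay, at which 1 of the 4 values shown sits.

The compounds shown leave open whether the ring itself or the added carbon count accounts for the step. A plain cyclohexyl group, without the carboxylic acid, and a longer open chain ending in a carboxylic acid would separate these readings.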